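A few compounds are considered here, and "the series" means these few. Any claim that something is new, unique, unknown or untested is made for them only; others in the source may bear on it.

Measured so far in a physicochemical assay for lipophilicity, at pH 7.4; on this read-out lower numbers stand for lower lipophilicity and higher numbers for higher lipophilicity:
- compound 1 `C[C@H]1C(=O)N(C)C=Cc2cc(C(CO)CO)ccc21` at 1.2
- compound 2 `CCS(=O)(=O)c1ccc2c(c1)C=CN(C)C(=O)[C@@H]2C` at 3.1

Of these two, compound 2 stands highest. Going by the values given here, the one measured step is a number 1.90 log units higher from compound 1 to compound 2 (beyond the scatter) and it comes with ethylsulfonyl in place of 2-hydroxy-1-(hydroxymethyl)ethyl on an aromatic carbon.

Next is compound 3 `CCS(=O)(=O)c1ccc2c(c1)C(C)=CN(C)C(=O)[C@@H]2C` which differs from compound 2 by methyl in place of hydrogen on a double-bonded ring carbon and by nothing else. The measured step is large, but it concerns a different group in a different place, so its size is a poor guide here. Among the compounds with values here, no measured step covers a methyl. The expectation therefore starts from compound 2 at 3.1 and allows only a modest move. A small upward step is expected, estimated as a number 0.40 log units higher from compound 2 to compound 3 (beyond the scatter) in this assay readings. For compound 3 the estimated value is 3.5 with an expected range from 3.1 to 3.9 on the same scale.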

Compound 3, distribution coefficient: 3.4
Compound 3: the middle estimate sits 0.10 log units above what was measured, and the stated range covers the measured number.
By their numbers in this assay, from the lowest: compound 1; then compounds 2 and 3 (each within the scatter of the next).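

Methyl in place of hydrogen on a double-bonded ring carbon, two ring bonds from the ring nitrogen, comes with a number 0.30 log units higher from compound 2 to compound 3 (within the scatter) in this assay. Going by these compounds alone, this is the first reading at this position of the seven-membered ring, since the earlier step concerned only the group on the aromatic carbon, and on this read-out compound 2 and compound 3 cannot be told apart, so this one added carbon at this place leaves the number within the scatter. No measurement at hand speaks to what lies behind this reading.

Still open, as far as these compounds go, is whether a group other than methyl at this ring carbon, such as an ethyl, a hydroxymethyl or an aminomethyl group, would also stay within the scatter of compound 2 or would move the number beyond it. Also open, from the compounds shown here alone, is whether the same methyl gives a comparable step when the aromatic carbon carries 2-hydroxy-1-(hydroxymethyl)ethyl, as in compound 1, in place of ethylsulfonyl.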